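The source may hold more compounds than are shown below. What is called first, only, known or untested is meant among the compounds shown, and "the series" means these compounds.

Compound 1 `N#CC1=C(N)Oc2c(N)cc3nc4ccccc4nc3c2C12C(=O)N(Cc1cnnn1-c1cccc(Br)c1)c1ccccc12` gives 18900 nM in a functional assay on A549 cells (Homo sapiens) for antiproliferative activity, read by MTT assay, with a stated time of 48 h; on this read-out higher numbers stand for weaker inhibition and lower numbers for stronger inhibition. For compound 2 `COc1ccc(-n2nncc2CN2C(=O)C3(C(C#N)=C(N)Oc4c(N)cc5nc6ccccc6nc5c43)c3ccccc32)cc1` this assay reports only a limit, > 50000 nM. Compound 3 `COc1ccccc1-n1nncc1CN1C(=O)C2(C(C#N)=C(N)Oc3c(N)cc4nc5ccccc5nc4c32)c2ccccc21` gives 37500 nM in this assay, the higher of the two numbers measured; its nearest neighbour is compound 1, with a 2.0-fold higher number from compound 1 to compound 3 (0.30 log units; within the scatter). The other measured steps are an at least 2.6-fold higher number from compound 1 to compound 2 (0.42 log units; beyond the scatter) and an at least 1.3-fold lower number from compound 2 to compound 3 (0.12 log units; that floor lies within the scatter). Compound 4 `Cc1ccc(C)c(-n2nncc2CN2C(=O)C3(C(C#N)=C(N)Oc4c(N)cc5nc6ccccc6nc5c43)c3ccccc32)c1` carries 2,5-dimethylphenyl in place of 2-methoxyphenyl on an aromatic nitrogen. The measured steps on this aromatic nitrogen stay within or barely beyond the scatter, so compound 4 is expected to show no step beyond the scatter, a 1.3-fold lower number from compound 3 to compound 4 (0.10 log units; within the scatter). Compound 4 is therefore estimated at 30000 nM in this assay, with a range from 12000 nM to 60000 nM.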

Compound 4, half-maximal inhibitory concentration: > 50000 nM
Compound 4 ended at the assay's limit (the forecaster's own chance of this, stated with the estimate: 25%); at least 1.6-fold (0.22 log units) between middle value and limit.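

In this assay, 2,5-dimethylphenyl in place of 2-methoxyphenyl, a swap that removes the group's one hydrogen-bond acceptor, gives an at least 1.3-fold higher number from compound 3 to compound 4 (0.12 log units; that floor lies within the scatter), so this change is not shown to pass the scatter. Against 3-bromophenyl, the same group gives an at least 2.6-fold higher number from compound 1 to compound 4 (0.42 log units; beyond the scatter), making it the second group after 4-methoxyphenyl to stand clearly apart from 3-bromophenyl, though 2-methoxyphenyl in compound 3 does not. The step from compound 2 to compound 4 cannot be read, because both values are limits: the limit of > 50000 nM in this assay, at which 2 of the 4 values shown sit.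

As far as these compounds go, it remains open whether a 3-chlorophenyl or pyridyl group on this nitrogen would give a lower number than compound 1.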